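This account rests on a few compounds, and the source may have more. Where it says the series, first, only, none or still open, it means among the compounds named here.

Compound 1 `COc1ccc(C2=NN(C3=NC(=O)/C(=C4\C(=O)Nc5ccc(Br)cc54)S3)C(c3ccc(OC)cc3)C2)cc1` gives 430 nM in a functional assay on cells (Cancer cell lines, Homo sapiens) for cytotoxicity, read by sulforhodamine B assay, with a stated time of 48 h; a higher number here means a weaker inhibitor of growth, a lower number a stronger inhibitor of growth. Compound 2 `COc1ccc(C2=NN(C3=NC(=O)/C(=C4\C(=O)Nc5ccc(Cl)cc54)S3)C(c3ccc(OC)cc3)C2)cc1` gives 440 nM in this assay. Compound 3 `COc1ccc(-c2cc(-c3ccc(Cl)cc3)n(C3C(=O)Nc4ccc(Br)cc43)n2)cc1` gives 30000 nM in this assay.

Compound 1 and compound 2 share one core and differ only by chloro in place of bromo on an aromatic carbon; that step is a 1.0-fold higher number from compound 1 to compound 2 (0.01 log units; within the scatter). Compound 3 sits on a different core, and the difference between the two cores is not broken down here; compound 3 stands far weaker than compound 1 and compound 2 in this assay. Compound 4 `COc1ccc(-c2cc(-c3ccc(Cl)cc3)n(C3C(=O)Nc4ccc(Cl)cc43)n2)cc1` has not yet been measured. It differs from compound 3 by chloro in place of bromo on an aromatic carbon, the same change, at the same place, as that from compound 1 to compound 2. Since the step of a 1.0-fold higher number from compound 1 to compound 2 (0.01 log units; within the scatter) stayed within the scatter, compound 4 is expected to shift by only no change at the digits printed from compound 3 to compound 4 (within the scatter). Compound 4 is therefore estimated at 30000 nM, between 15000 nM and 60000 nM.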

Compound 4, concentration for total growth inhibition: 23200 nM
Estimate against measurement, compound 4: 1.3-fold (0.11 log units) above; the range from low to high includes it.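

In this assay, chloro in place of bromo on an aromatic carbon gives a 1.3-fold lower number from compound 3 to compound 4 (0.11 log units; within the scatter), and the step on this core does not differ from the one on the core of compound 1: the same change on two cores in this assay, a 1.0-fold higher number (0.01 log units; within the scatter) from compound 1 to compound 2 and a 1.3-fold lower number (0.11 log units; within the scatter) from compound 3 to compound 4, 1.3-fold (0.12 log units) apart, within the scatter of two such steps. On these two cores, then, the change carries over and leaves the reading unmoved beyond the scatter. This rests on two pairs only; it does not show that the change would behave alike on any other core, nor that the group at this place is unimportant.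

The compounds shown leave open whether a fluoro, a nitrile or an amine at the same place would read like bromo and chloro. They also leave open what removing the halogen altogether would do.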